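Replacing the Acyl Group with Naphthalenyl on the Thiourea

The source may report more compounds than this note shows. Statements on the series, on what has been measured and on what is new or still open speak of the compounds shown alone.

Of the compounds shown here, three sharing one core have been tested in an ADME assay on Huh-7 cells (Homo sapiens) for cytotoxicity; on this read-out higher numbers stand for weaker inhibition and lower numbers for stronger inhibition. Compound 1 `CN(c1cc2ncc(=O)[nH]c2cc1NC(=S)NC(=O)c1ccc(OC(F)(F)F)cc1)C1CCCCC1` gives 6470 nM. Compound 2 `COc1cc(C(=O)NC(=S)Nc2cc3[nH]c(=O)cnc3cc2N(C)C2CCCCC2)cc(OC)c1OC` gives 15900 nM, and compound 3 `CN(c1cc2ncc(=O)[nH]c2cc1NC(=S)NC(=O)c1ccc(Cl)nc1)C1CCCCC1` gives 34500 nM, the highest of the three numbers. The measured steps are a 2.5-fold higher number from compound 1 to compound 2 (0.39 log units; beyond the scatter), a 5.3-fold higher number from compound 1 to compound 3 (0.73 log units; beyond the scatter) and a 2.2-fold higher number from compound 2 to compound 3 (0.34 log units; beyond the scatter); each swaps one aryl group on the carbonyl carbon while the acyl thiourea itself stays in place. Compound 4 `CN(c1cc2ncc(=O)[nH]c2cc1NC(=S)Nc1cccc2ccccc12)C1CCCCC1` differs from compound 3 by naphthalen-1-yl in place of (6-chloropyridin-3-yl)carbonyl on an amide-type nitrogen. Going by the values given here, no measured step covers removal of the carbonyl together with the exchange of the aryl group, so the three aryl swaps bear on it only loosely; they show that changes of the group attached through the amide-type nitrogen moved this assay by modest amounts. A modest shift in either direction is therefore plausible for compound 4, and a number near the middle of the measured range is expected. The step from compound 3 to compound 4 is estimated as a 1.7-fold lower number from compound 3 to compound 4 (0.24 log units; within the scatter). Compound 4 is expected to give about 20000 nM in this assay, within a range of 5000 nM to 70000 nM.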

Compound 4, half-maximal inhibitory concentration: 43600 nM
The estimate for compound 4 lay 2.2-fold (0.34 log units) below the measured number; the measured number falls inside the stated range.
By their numbers in this assay, from the lowest: compound 1; then compound 2; then compounds 3 and 4 (each within the scatter of the next).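

In this assay, the step of a 1.3-fold higher number from compound 3 to compound 4 (0.10 log units; within the scatter) is the first one shown that removes the carbonyl from the acyl thiourea, and it stays within the scatter. On this amide-type nitrogen, whose other neighbour is the thiocarbonyl carbon, a directly attached naphthalen-1-yl therefore reads the same as (6-chloropyridin-3-yl)carbonyl, although the entering group has no hydrogen-bond acceptors and the leaving group has 2. Nothing available explains this result.

Because the loss of the carbonyl and the exchange of the aryl group fall in one step, the compounds shown cannot assign any part of the outcome to either change. Going by these compounds, it remains open what a naphthalen-1-ylcarbonyl group would give on this nitrogen, and whether a plain phenyl or an aminoethyl chain there would read differently.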